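The source may hold more compounds than are shown below. What is called first, only, known or untested is meant among the compounds shown, and "the series" means these compounds.

Of the compounds shown here, three sharing one core have been measured in a functional assay on MCF7 cells (Homo sapiens) for cytotoxicity, read by MTT assay, with a stated time of 48 h; a higher number here means a weaker inhibitor, a lower number a stronger inhibitor. Compound 1 `NNC(=O)CSc1nnc(-c2ccncc2)o1` gives 3260 nM, compound 2 `O=C(CSc1nnc(-c2ccncc2)o1)N/N=C/c1ccc(F)cc1` gives 13500 nM, and compound 3 `O=C(CSc1nnc(-c2ccncc2)o1)N/N=C/c1ccc(O)cc1` gives 11700 nM. Compound 3 therefore sits level with compound 2 within the scatter, and the numbers of both are higher than that of compound 1.

Compound 4 `O=C(CSc1nnc(-c2ccncc2)o1)N/N=C/c1cccc(F)c1` has not yet been measured. It differs from compound 3 as follows: 3-fluorophenyl in place of 4-hydroxyphenyl on a carbon with a double bond to nitrogen. In words, it has 3-fluorophenyl in place of 4-hydroxyphenyl on a carbon with a double bond to nitrogen.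

Within the data shown here, only one measured step bears on this change. Between the two compounds that exchange fluoro and hydroxy on an aromatic carbon, the result was a 1.2-fold lower number from compound 2 to compound 3 (0.06 log units; within the scatter), which is within the scatter. Among the measured compounds shown here, that step offers a guide to the exchange of the two groups, but no measured compound carries the 3-fluorophenyl group, so the data leave its effect open. No shift beyond the scatter is therefore expected in this assay, and no direction can be favoured. The estimated change is small, a 1.1-fold higher number from compound 3 to compound 4 (0.03 log units; within the scatter). Compound 4 is expected at 12500 nM, with an estimated range from 6000 nM to 26000 nM.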

Compound 4, half-maximal inhibitory concentration: 24900 nM
Estimate against measurement, compound 4: 2.0-fold (0.30 log units) below; the measured number falls inside the stated range.
By their numbers in this assay, from the lowest: compound 1; then compounds 3, 2 and 4 (each within the scatter of the next, the first and the last beyond it).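

Compound 4 is the only compound shown with the 3-fluorophenyl group on the carbon with a double bond to nitrogen, and in this assay it gives a step beyond the scatter from the hydroxy compound: a 2.1-fold higher number from compound 3 to compound 4 (0.33 log units; beyond the scatter). The exchange of fluoro and hydroxy within the 4-substituted phenyl group had stayed within the scatter, at a 1.2-fold lower number from compound 2 to compound 3 (0.06 log units; within the scatter), so this position can respond to a change of aryl group, though only modestly, while the step that moves the fluoro alone, a 1.8-fold higher number from compound 2 to compound 4 (0.27 log units; within the scatter), stays within the scatter. The replacement in compound 4 thus alters both the substituent and its place on the ring, and the data do not divide the step between the two, nor does any other kind of measurement accompany these numbers to account for it.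

Going by these compounds, whether a 3-hydroxyphenyl group would separate the two parts of this change remains open. So does the response of this position to a methoxy group, an amine or a carboxylic acid on the aromatic ring.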